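From hydroxy to methoxy on the shared core

The compounds below may be only part of what the source reports. "The series", "measured", "known", "first", "only" and "open" are said of these compounds alone.

In a functional assay on HepG2 cells (Homo sapiens) for cytotoxicity, read by MTT assay (a lower number here means a stronger inhibitor, a higher number a weaker inhibitor), compound 1 (`COc1cc(O)c(C=O)c2c1[C@H](O)C[C@@H](c1ccccc1)O2`) is reported as "not active" (no number reported) and carries no number, so it has no exact place on the scale. Going by the values given here, the only number nearby comes from compound 2 (`COc1c(C)c(OC)c2c(c1C=O)O[C@H](c1ccccc1)C[C@H]2O`), which gives 99600 nM in the same read-out and so counts as a very weak inhibitor. Compound 3 (`COc1cc(O)c(C=O)c2c1[C@H](OC)C[C@@H](c1ccccc1)O2`) keeps the core of compound 1 and differs from it in one place, methyl in place of hydrogen on an oxygen on a saturated carbon (methyl in place of hydrogen on an oxygen on a saturated carbon, which reads as hydroxy to methoxy). Among the compounds with values here, no pair of measured compounds shows what this change does, so the expectation is a loose one. In this assay only a small step is expected, from no measurable inhibition toward weak inhibition, and there may be none at all. That expectation leans on compound 2 with its 99600 nM as the sole anchor, and compound 3 may equally be reported without a number. The estimate for compound 3 is 80000 nM as the expected value, with an expected range from 30000 nM to 200000 nM around it.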

Compound 3, half-maximal inhibitory concentration: "not active" (no number reported)
For compound 3 the study gives words and no number; the estimate stays without a comparison.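

In this assay, going by these compounds alone, compound 1 is reported as "not active" (no number reported) and compound 3 as "not active" (no number reported), so no step from hydroxy to methoxy can be read from this pair. No measured evidence bears on this result. The compounds shown leave open whether this change alters inhibition at all.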